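This account rests on a few compounds, and the source may have more. Where it says the series, first, only, none or still open, it means among the compounds named here.

Measured in a physicochemical assay for lipophilicity, read by HPLC, at pH 7.4; a higher number here means a more lipophilic compound, a lower number a more polar compound:
Compound 1 `CNCc1cn(S(=O)(=O)c2cccc(OC)n2)c(-c2cccnc2F)c1F`: 1.03
Compound 2 `CNCc1cn(S(=O)(=O)c2cccc(C)n2)c(-c2cccnc2F)c1F`: 0.71
Compound 3 `CNCc1cn(S(=O)(=O)c2cccnc2C)c(-c2cccnc2F)c1F`: 0.48

Two steps place compound 3 among these: a number 0.23 log units lower from compound 2 to compound 3 (within the scatter), and a number 0.55 log units lower from compound 1 to compound 3 (beyond the scatter). Compound 4 `CNCc1cn(S(=O)(=O)c2cnccc2C)c(-c2cccnc2F)c1F`, not yet measured, keeps the shared core and changes only the group on the sulfonyl sulfur 4-methylpyridin-3-yl in place of 2-methylpyridin-3-yl on a sulfonyl sulfur: 4-methylpyridin-3-yl in place of 2-methylpyridin-3-yl. The two have the same atoms, joined differently.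

The closest measured comparison is the exchange of 6-methylpyridin-2-yl for 2-methylpyridin-3-yl, a number 0.23 log units lower from compound 2 to compound 3 (within the scatter). The steps from compound 1, such as a number 0.32 log units lower from compound 1 to compound 2 (beyond the scatter), bear less on this change, since they remove a methoxy group that neither compound 3 nor compound 4 carries. Among the measured compounds shown here, no measured compound has the 4-methylpyridin-3-yl group, so the expectation rests on that single comparison. No shift beyond the scatter is therefore expected in this assay, and the expected step is a number 0.02 log units higher from compound 3 to compound 4 (within the scatter). The estimate for compound 4 is 0.5, with an expected range from 0.15 to 0.85.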

Compound 4, distribution coefficient: 0.43
Estimate against measurement, compound 4: 0.07 log units above, within the range that was stated.
By their numbers in this assay, from the lowest: compounds 4, 3 and 2 (each within the scatter of the next); then compound 1.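

With the same atoms joined differently, 4-methylpyridin-3-yl in place of 2-methylpyridin-3-yl on the sulfonyl sulfur gives no distinction in this assay (a number 0.05 log units lower from compound 3 to compound 4 (within the scatter)). The comparison with the 6-methylpyridin-2-yl group also stays within the scatter (a number 0.28 log units lower from compound 2 to compound 4 (within the scatter)), so all three methylpyridinyl groups shown cannot be told apart in this assay, while the 6-methoxypyridin-2-yl group remains apart from this set (a number 0.60 log units lower from compound 1 to compound 4 (beyond the scatter)). Nothing available here explains why these numbers fall as they do.

As far as these compounds go, it remains open whether a phenyl group, or a methylpyridinyl group carrying a carboxylic acid or an amine, on the sulfonyl sulfur would stay with these three. From the compounds shown here alone, it is also open whether the 4-methylpyridin-3-yl and 2-methylpyridin-3-yl groups would differ in any other assay.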